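Ester chain length and cytotoxicity in a naphthoquinone series

A few compounds are considered here, and "the series" means these few. Any claim that something is new, unique, unknown or untested is made for them only; others in the source may bear on it.

Of the compounds shown here, three sharing one core have been measured. Compound 1 `CCCCCC(=O)OCC(C)(C)CC1=C(O)C(=O)c2ccccc2C1=O` carries the shortest ester chain; in a functional assay on KB cells (Homo sapiens) for cytotoxicity, read by resazurin assay, with a stated time of 3 days (a lower number here means a stronger inhibitor, a higher number a weaker inhibitor), compound 1 gives 41000 nM. Compound 2 `CCCCCCCC(=O)OCC(C)(C)CC1=C(O)C(=O)c2ccccc2C1=O` differs from it by ethyl in place of hydrogen on a saturated chain carbon, five bonds along the chain from a carbonyl carbon, and in this assay compound 2 gives 38300 nM; the step of a 1.1-fold lower number from compound 1 to compound 2 (0.03 log units; within the scatter). Compound 3 `CCCCCCCCCCCC(=O)OCC(C)(C)CC1=C(O)C(=O)c2ccccc2C1=O` differs from compound 1 by hexyl in place of hydrogen on a saturated chain carbon, five bonds along the chain from a carbonyl carbon, and in this assay compound 3 gives 35700 nM. The unmeasured compound 4 `CCCCCCCCCCCCCC(=O)OCC(C)(C)CC1=C(O)C(=O)c2ccccc2C1=O` differs from compound 3 by ethyl in place of hydrogen on a saturated chain carbon, ten or more bonds along the chain from a carbonyl carbon. This is the same kind of change as that from compound 1 to compound 2, though at a different place on the chain. Because a 1.1-fold lower number from compound 1 to compound 2 (0.03 log units; within the scatter) and a 1.1-fold lower number from compound 2 to compound 3 (0.03 log units; within the scatter) both lie within the scatter, the step of a 1.1-fold lower number from compound 3 to compound 4 (0.03 log units; within the scatter) is expected to be similarly small, and compound 4 is estimated at 33000 nM, between 17000 nM and 66000 nM.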

Compound 4, half-maximal inhibitory concentration: 51400 nM
Estimate against measurement, compound 4: 1.6-fold (0.19 log units) below; low and high end bracket the measured number.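

In this assay, ethyl in place of hydrogen gives a 1.4-fold higher number from compound 3 to compound 4 (0.16 log units; within the scatter), and this agrees with the earlier ethyl step: the same change on two cores in this assay, a 1.1-fold lower number (0.03 log units; within the scatter) from compound 1 to compound 2 and a 1.4-fold higher number (0.16 log units; within the scatter) from compound 3 to compound 4, 1.5-fold (0.19 log units) apart, within the scatter of two such steps
Hexyl in place of hydrogen gives a 1.3-fold higher number from compound 2 to compound 4 (0.13 log units; within the scatter), and this also agrees with its earlier counterpart: the same change on two cores in this assay, a 1.1-fold lower number (0.06 log units; within the scatter) from compound 1 to compound 3 and a 1.3-fold higher number (0.13 log units; within the scatter) from compound 2 to compound 4, 1.5-fold (0.19 log units) apart, within the scatter of two such steps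
Octyl in place of hydrogen gives a 1.3-fold higher number from compound 1 to compound 4 (0.10 log units; within the scatter), so each chain extension behaves alike on these closely related cores within the scatter, but with every step this small, the series shows no real effect that could be carried from one core to another.

Going by these compounds, whether a longer chain, or a chain ending in an amine or a carboxylic acid, would shift the number beyond the scatter remains open. So does the effect of an amide in place of the ester.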